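This account rests on a few compounds, and the source may have more. Where it says the series, first, only, none or still open, it means among the compounds named here.

Compound 1 `O=C(N[C@H]1C(O)O[C@H](CO)[C@@H](O)[C@@H]1O)c1ccc(-c2ccccc2)cc1` gives the highest number of the three in hand: in an assay for inhibition of hexokinase-1 (Homo sapiens), read by ADP-Glo, with a stated time of 45 min, in the presence of a further agent that is not named here (on this read-out higher numbers stand for weaker inhibition and lower numbers for stronger inhibition), compound 1 gives 13000 nM. Compound 2 `Cc1oc(S(=O)(=O)NC[C@H]2OC(O)[C@H](NC(=O)c3cccc(Br)c3)[C@@H](O)[C@@H]2O)cc1C(=O)O` gives 20 nM in this assay, the lowest of the three numbers in hand. Compound 3 `O=C(O)c1cccc(S(=O)(=O)NC[C@H]2OC(O)[C@H](NC(=O)c3cccc(-c4ccccc4)c3)[C@@H](O)[C@@H]2O)c1` gives 25 nM in this assay; its gap to compound 2 lies within the scatter, so the two cannot be placed in order. Compound 1 stands far above both, well beyond the scatter, and is the only clear separation in the set.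

Compound 4 `COC(=O)c1cc(S(=O)(=O)NC[C@H]2OC(O)[C@H](NC(=O)c3cccc(Br)c3)[C@@H](O)[C@@H]2O)oc1C` has not yet been measured. It differs from compound 2 in one place: methyl in place of hydrogen on an oxygen next to a carbonyl group. Going by the values given here, no measured pair carries this change, so nothing in hand fixes its size or its direction. The step expected from compound 2 to compound 4 a 5.0-fold higher number from compound 2 to compound 4 (0.70 log units; beyond the scatter) is a rise that may reach beyond the scatter, held with little confidence. Compound 4 is estimated at 100 nM in this assay, with a range from 20 nM to 600 nM.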

Compound 4, half-maximal inhibitory concentration: 1600 nM
Compound 4: middle estimate off by 16-fold (1.20 log units), on the low side; measured number above the stated range.
By their numbers in this assay, from the lowest: compounds 2 and 3 (each within the scatter of the next); then compound 4; then compound 1.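

In this assay, going by these compounds alone, the change from carboxy to methoxycarbonyl gives an 80-fold higher number from compound 2 to compound 4 (1.90 log units; beyond the scatter) and is the first step that can be read at one place. A single methyl on an oxygen next to a carbonyl group is therefore enough to carry the number far beyond the scatter. With the rest of compound 2 held fixed, the hydrogen at this place cannot be replaced by methyl without a large loss of inhibition.

Going by these compounds, it remains open whether this loss is particular to the methyl ester or extends to other replacements such as a carboxamide, a tetrazole or ethoxycarbonyl, and whether the same change would carry over to the core of compound 3. Nothing in hand gives a reason for the size of this step.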